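The compounds below may be only part of what the source reports. "The series", "measured", "known", "first", "only" and "open" are said of these compounds alone.

Measured so far: compound 1 `COc1cc(NC(C)CCCNC(=O)/C=C/c2cc(OC)c(OC)c(OC)c2)c2ncccc2c1`, > 210000 nM; compound 2 `COc1cc(NC(C)CCCNC(=O)Nc2ccc(Cl)c(C(F)(F)F)c2)c2ncccc2c1`, "not determined" (no result reported).

Compound 1 shares its core with compound 2; in an ADME assay on L6 cells (Rattus norvegicus) for cytotoxicity, read by resazurin assay, with a stated time of 70 h (a lower number here means a stronger inhibitor, a higher number a weaker inhibitor), compound 1 gives only a limit, > 210000 nM, and not a number. Compound 2 differs from compound 1 in the part that hangs off the amide nitrogen, and in this assay compound 2 has no result reported. So compound 2 stands on no number of its own; the one value shown beside it is a limit (the limit of > 210000 nM in this assay, at which 1 of the 2 values shown sits).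

Compound 3 `COc1cc(NC(C)CCCNC(=O)NNC(=O)N(CCO)CCO)c2ncccc2c1` is not yet measured. It differs from compound 2 in one place: (bis(2-hydroxyethyl)carbamoyl)amino in place of 4-chloro-3-(trifluoromethyl)phenyl on an amide-type nitrogen.

Within the data shown here, no step between measured compounds exists here, so the size of the change in this assay from compound 2 to compound 3 cannot be read from any pair. Among the measured compounds shown here, the only reading is the limit of compound 1, which gives no direction at all; no step beyond the usual scatter is expected in either direction. Compound 3 is therefore expected to sit at about 200000 nM, within 50000 nM to 400000 nM, with a fair chance that only a limit is reported.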

Compound 3, half-maximal inhibitory concentration: 178000 nM
For compound 3 the middle estimate is 1.1-fold (0.05 log units) above the measured one; the measured number falls inside the stated range.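

No new step can be read: in this assay compound 2 carries no number, so compound 3 has no partner to be compared with. Compound 1 offers only a limit: the limit of > 210000 nM in this assay, at which 1 of the 3 values shown sits.

The compounds shown leave open what exchanging 4-chloro-3-(trifluoromethyl)phenyl for (bis(2-hydroxyethyl)carbamoyl)amino on the amide-type nitrogen does in this assay.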